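The compounds below may be only part of what the source reports. "The series", "measured", "known", "first", "only" and "open" are said of these compounds alone.

Measured compounds, in an ADME assay on cells (Epithelial cell, Homo sapiens) for cytotoxicity, read by MTT assay, with a stated time of 24 h; on this read-out lower numbers stand for higher toxicity in this test and higher numbers for lower toxicity in this test:
- compound 1 `CC(=O)OC[C@H]1O[C@@H](CC(=O)/C=C/c2cccnc2)[C@H](OC(C)=O)[C@@H](OC(C)=O)[C@@H]1OC(C)=O`: 4.17 nM
- compound 2 `CC(=O)OC[C@H]1O[C@@H](CC(=O)/C=C/c2ccc(OCc3ccccc3)cc2)[C@H](OC(C)=O)[C@@H](OC(C)=O)[C@@H]1OC(C)=O`: "not determined" (no result reported)

Only compound 1 carries a number in this assay, and compound 1 gives 4.17 nM. Compound 2 stands without a number in this assay, so it gives no fixed point from which a step can be measured, and no comparison between compound 1 and compound 2 can be drawn on these values. The next compound, compound 3 `CC(=O)OC[C@H]1O[C@@H](CC(=O)/C=C/c2ccc(C(F)(F)F)cc2)[C@H](OC(C)=O)[C@@H](OC(C)=O)[C@@H]1OC(C)=O`, differs from compound 2 in one place, (trifluoromethyl in place of benzyloxy on an aromatic carbon), while the shared sugar-like core with its four acetate groups and the unsaturated ketone linker stay as they are. With no number for compound 2, no size or direction of step can be stated for this change in this assay. Resting on compound 1 alone, compound 3 is expected to give about 15 nM in this assay, within a wide range from 1.5 nM to 300 nM.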

Compound 3, half-maximal cytotoxic concentration: 103 nM
Compound 3: the middle estimate sits 6.9-fold (0.84 log units) below what was measured; measured number inside the range.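

Replacing pyridin-3-yl with 4-(trifluoromethyl)phenyl on a double-bonded chain carbon, with the rest of the structure unchanged, gives a 25-fold higher number from compound 1 to compound 3 (1.39 log units; beyond the scatter) in this assay. Going by these compounds alone, this is the first readable step, and it shows that the group at this position can shift the result well beyond the usual scatter, towards lower toxicity in this test. No measurement here explains the size of this step.

The change from compound 2 to compound 3 cannot be read, and the swap from pyridin-3-yl to 4-(trifluoromethyl)phenyl alters both the ring and its substituent, so the two contributions cannot be separated. As far as these compounds go, how a plain phenyl, or a phenyl carrying an amine or a carboxylic acid in place of trifluoromethyl, would behave in this assay remains open.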